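The compounds below may be only part of what the source reports. "The series", "measured", "known", "first", "only" and "open" are said of these compounds alone.

Three compounds share one core and differ only in the aryl group attached to a carbonyl carbon. Compound 1 `COc1cc(-c2nnc3n2NC(c2ccco2)C(C(=O)c2ccc(Cl)cc2)S3)cc(OC)c1OC` carries a 4-chlorophenyl there, compound 2 `COc1cc(-c2nnc3n2NC(c2ccco2)C(C(=O)c2cccc4ccccc24)S3)cc(OC)c1OC` a naphthalen-1-yl, and compound 3 `COc1cccc(C(=O)C2Sc3nnc(-c4cc(OC)c(OC)c(OC)c4)n3NC2c2ccco2)c1` a 3-methoxyphenyl. In a functional assay on MCF7 cells (Homo sapiens) for cytotoxicity, read by MTT assay, with a stated time of 48 h (a higher number here means a weaker inhibitor, a lower number a stronger inhibitor), compound 1 gives only a limit of the assay, > 100000 nM. Compound 2 also reaches only a limit, > 100000 nM. Compound 3 likewise gives only a limit, > 100000 nM. Because all three sit at the limit of > 100000 nM in this assay, at which 3 of the 3 values shown sit, none of the steps between them can be read: a step that the two limits leave unreadable from compound 1 to compound 2, a step that the two limits leave unreadable from compound 1 to compound 3 and a step that the two limits leave unreadable from compound 2 to compound 3. Compound 3 therefore stands nowhere in particular on the numbers shown; it cannot be told apart from compound 1 or compound 2, each at the same limit.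

Compound 4 `COc1cc(-c2nnc3n2NC(c2ccco2)C(C(=O)c2ccco2)S3)cc(OC)c1OC` is not yet measured. It differs from compound 3 in one place: furan-2-yl in place of 3-methoxyphenyl on a carbonyl carbon. The measured steps bear on this change only in that every exchange of the aryl group on that carbonyl carbon has so far left the value at the limit, so no step size in any direction can be taken from them. The expectation is that compound 4 also gives no readable number, an estimated step of a number no higher from compound 3 to compound 4 (the limit leaves the size open). The estimated value for compound 4 is 100000 nM, within a range from 30000 nM to 300000 nM.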

Compound 4, half-maximal inhibitory concentration: > 100000 nM
Compound 4: only a limit was reported; the forecaster's own chance of this, stated with the estimate: 85%; the middle value lies on the limit itself.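

Compound 4 gives only a limit of this assay, > 100000 nM. No step from compound 1, compound 2 or compound 3 to compound 4 can be read, because all four compounds stand at one limit: the limit of > 100000 nM in this assay, at which 4 of the 4 values shown sit.

The compounds shown leave open whether exchanging the group on the carbonyl carbon changes the result in this assay at all, and in which direction.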